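Swapping pyridin-2-yl for 4-(trifluoromethyl)phenyl: an estimate

The source may hold more compounds than are shown below. What is called first, only, known or untested is meant among the compounds shown, and "the series" means these compounds.

Compound 3 `O=C(NO)c1ccc(NCc2nc(-c3ccccn3)nn2-c2ccccc2)cc1` gives 58.6% in an assay on Sf9 cells for inhibition of protein deacetylase HDAC6 (Homo sapiens), read by fluorescence, with a stated time of 40 min, tested at 100 nM; a higher number here means more inhibition at the concentration tested (going by the name of the read-out), a lower number less inhibition. Among the three measured compounds it stands second highest: its nearest neighbour is compound 1 `Cc1ccc(-c2nc(CNc3ccc(C(=O)NO)cc3)n(-c3ccccc3)n2)o1` with 60.7%, and the step of a number 2.1 percentage points lower from compound 1 to compound 3 (within the scatter) lies within the scatter; compound 2 `Cc1ccccc1-c1nc(CNc2ccc(C(=O)NO)cc2)n(-c2ccccc2)n1` with 53.2% lies furthest, and a number 5.4 percentage points higher from compound 2 to compound 3 (within the scatter) is also within the scatter. Compound 4 `O=C(NO)c1ccc(NCc2nc(-c3ccc(C(F)(F)F)cc3)nn2-c2ccccc2)cc1` differs from compound 3 by 4-(trifluoromethyl)phenyl in place of pyridin-2-yl on an aromatic carbon. The measured steps that bear on this exchange the group on the same aromatic carbon: a number 2.1 percentage points lower from compound 1 to compound 3 (within the scatter) and a number 5.4 percentage points higher from compound 2 to compound 3 (within the scatter), neither beyond the scatter, and a number 7.5 percentage points lower from compound 1 to compound 2 (within the scatter) likewise. A change beyond the scatter in this assay is therefore not expected for compound 4. The estimate for compound 4 is 57%, in the range 44% to 70%, meaning an expected step of a number 1.6 percentage points lower from compound 3 to compound 4 (within the scatter).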

Compound 4, a percentage reported as inhibition, at one concentration (the size of the read-out at that concentration, not a potency): 41.6%
The estimate for compound 4 lay 15.4 percentage points above the measured number; measured number outside the range, below it.
By their numbers in this assay, from the lowest: compound 4; then compounds 2, 3 and 1 (each within the scatter of the next).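

On the aromatic carbon between two ring nitrogen atoms, the other three groups stay within the scatter of one another in this assay, but 4-(trifluoromethyl)phenyl moves the number beyond it in every comparison (a number 17 percentage points lower from compound 3 to compound 4 (beyond the scatter); a number 11.6 percentage points lower from compound 2 to compound 4 (beyond the scatter); a number 19.1 percentage points lower from compound 1 to compound 4 (beyond the scatter)). This position therefore does respond to the group it carries, and compound 4 stands lowest of the four. No evidence is available to account for this drop. The compounds shown leave open whether the trifluoromethyl group itself or its place on the phenyl ring sets this number, and how a phenyl ring bearing an amine or a carboxylic acid would read.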